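Swapping methyl for fluoro on two related cores

The source may hold more compounds than are shown below. What is called first, only, known or untested is meant among the compounds shown, and "the series" means these compounds.

This set of four compounds asks one question: what happens when a methyl group on an aromatic carbon is replaced by fluoro. Compound 1 `Cc1ccc2c(=O)[nH]c(-c3ccccc3C)nc2c1` and compound 3 `Cc1ccc2c(=O)[nH]c(-c3ccccc3F)nc2c1` share one core. Compound 2 `Cc1ccc2nc(-c3ccccc3C)[nH]c(=O)c2c1` and compound 4 `Cc1ccc2nc(-c3ccccc3F)[nH]c(=O)c2c1` share another, built from the same atoms as compound 1 but joined differently; the difference between the two cores is not broken down here.

All values come from a functional assay on HeLa cells (Homo sapiens) for cytotoxicity, read by MTT assay, with a stated time of 2 days; a lower number here means a stronger inhibitor, a higher number a weaker inhibitor. In this assay compound 1 reaches only the limit of > 50000 nM, so no number is known for it. Compound 3, in this assay, gives 830 nM, and compound 2 gives 4580 nM.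

The change from compound 1 to compound 3 is fluoro in place of methyl on an aromatic carbon. It produced an at least 60-fold lower number from compound 1 to compound 3 (1.77 log units; beyond the scatter). Because the starting point sits at the limit of > 50000 nM in this assay, at which 1 of the 3 values shown sits, the true size of that step is not known, only that it is large.

The change from compound 2 to compound 4 is fluoro in place of methyl on an aromatic carbon, the same change on the other core. Since compound 2 already gives a number rather than a limit, the step is expected to be smaller than the earlier one, estimated at a 5.7-fold lower number from compound 2 to compound 4 (0.76 log units; beyond the scatter). On that basis compound 4 is expected to reach about 800 nM in this assay, most likely between 200 nM and 3000 nM.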

Compound 4, half-maximal inhibitory concentration: > 50000 nM
Compound 4 gave a limit, no number; the forecaster's own chance of this, stated with the estimate: 5%; at least 62-fold (1.79 log units) between middle value and limit.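

In this assay compound 4 reaches only a limit of the assay, > 50000 nM, and not a number. The swap of methyl for fluoro therefore goes the opposite way on this core, with an at least 10-fold higher number from compound 2 to compound 4 (1.03 log units; beyond the scatter), and a gain seen on one core in this series cannot be assumed to carry over to the other: the same change on two cores in this assay, an at least 60-fold lower number (1.77 log units; beyond the scatter) from compound 1 to compound 3 and an at least 10-fold higher number (1.03 log units; beyond the scatter) from compound 2 to compound 4, at least 650-fold (2.81 log units) apart, beyond the scatter of two such steps. Each of the two steps has a limit at one end, so only a minimum size is known for either, and two cores cannot show why the direction reverses or how a third core would respond: the limit of > 50000 nM in this assay, at which 2 of the 4 values shown sit.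

The compounds shown leave open how other groups on that same aromatic carbon, such as chloro, methoxy or an amine, would behave on each core, and so whether the reversal is peculiar to fluoro or holds for other replacements of methyl. They also leave open how far compound 4 lies past its limit, and therefore how wide the true gap between the two steps is.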